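Adding a Side Chain to Compound 1

A few compounds are considered here, and "the series" means these few. Any claim that something is new, unique, unknown or untested is made for them only; others in the source may bear on it.

In a functional assay on MDA-MB-231 cells (Homo sapiens) for cytotoxicity, read by MTT assay, with a stated time of 24 h (a lower number here means a stronger inhibitor, a higher number a weaker inhibitor), compound 1 `COc1ccc2c(c1)cc(-c1cc(OC)c(OC)c(OC)c1)n2Cc1ccccc1` gives > 30000 nM, which is a limit of the assay and not a number. In this assay, the larger compound 2 `COc1ccc2c(c1)c(Cc1ccc(OCc3ccccc3)cc1)c(-c1cc(OC)c(OC)c(OC)c1)n2Cc1ccc(OCc2ccccc2)cc1` gives > 30000 nM, which is also a limit and not a number. For the measured compounds named here, the record so far is therefore (the limit of > 30000 nM in this assay, at which 2 of the 2 values shown sit), and no measured pair shows how far a single change can move the read-out.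

Compound 3 `COc1ccc2c(c1)cc(-c1cc(OC)c(OC)c(OC)c1)n2Cc1ccc(OC(C)CN(C)C)cc1` keeps the core of compound 1 and changes one place: 1-((dimethylamino)methyl)ethoxy in place of hydrogen on an aromatic carbon. In words, 1-((dimethylamino)methyl)ethoxy takes the place of hydrogen on an aromatic carbon, para to a large group.

Compound 1 at > 30000 nM is the only anchor for an expectation, and that value is a limit. The expected step of an at least 3.7-fold lower number from compound 1 to compound 3 (0.57 log units; beyond the scatter) in this assay points towards a stronger inhibitor, though its size is highly uncertain and the result could again be a limit. For compound 3 the estimated value is 8000 nM, with an expected range from 2000 nM to 30000 nM.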

Compound 3, half-maximal inhibitory concentration: 10600 nM
Beside the measured number, compound 3's estimate is 1.3-fold (0.12 log units) below it; measured number inside the range.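

Compound 3 is the only compound shown whose read-out in this assay is a number and not a limit, so it gives the first sign that this place, on an aromatic carbon para to a large group, can shift the result. Putting 1-((dimethylamino)methyl)ethoxy in place of hydrogen there gives an at least 2.8-fold lower number from compound 1 to compound 3 (0.45 log units; beyond the scatter). Compound 1 still offers only a limit and not a number, so this step has a floor but no known full size, and much of the record remains at that ceiling: the limit of > 30000 nM in this assay, at which 2 of the 3 values shown sit.

Going by these compounds, what stays open is which part of the new side chain matters, and a plain ethoxy, a longer chain ending in the same dimethylamino group, or a chain ending in a carboxylic acid at this place would each help to separate those parts. On these data alone, it is also open whether the same side chain would give a similar step at another place on that ring, and a single step cannot show this.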